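The source may report more compounds than this note shows. Statements on the series, on what has been measured and on what is new or still open speak of the compounds shown alone.

Three compounds share one core and were tested in an assay on HEK293 cells for agonist activity at transient receptor potential cation channel subfamily M member 8 (Homo sapiens), read by fluorescence and calcium flux, with a stated time of 15 min; a lower number here means that less compound is needed, a higher number that more compound is needed for the effect. Compound 1 `Cc1ccc(OCC(=O)N(Cc2cccs2)CC(C)C)cc1` gives 900 nM. Compound 2 `Cc1ccc(OCC(=O)N(Cc2cccs2)c2ccccn2)cc1` gives 200 nM. Compound 3 `Cc1ccc(OCC(=O)N(CCO)Cc2cccs2)cc1` gives 900 nM. Compound 3 therefore sits level with compound 1 at the digits shown, the two together being the highest numbers of the three, with compound 2 the furthest away, since a 4.5-fold higher number from compound 2 to compound 3 (0.65 log units; beyond the scatter).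

Compound 4 `Cc1ccc(OCC(=O)N(Cc2cccs2)c2ccn[nH]2)cc1` has not yet been measured. It differs from compound 3 in one place: 1H-pyrazol-5-yl in place of 2-hydroxyethyl on an amide-type nitrogen. The step that bears most directly on this is a 4.5-fold higher number from compound 2 to compound 3 (0.65 log units; beyond the scatter), where the group on that nitrogen went from pyridin-2-yl to 2-hydroxyethyl; the same nitrogen also gave a 4.5-fold lower number from compound 1 to compound 2 (0.65 log units; beyond the scatter). Compound 4 again carries a group with a five-membered aromatic ring with 2 hetero atoms on that nitrogen, so a modest fall in the number is expected, roughly a 3.0-fold lower number from compound 3 to compound 4 (0.48 log units; beyond the scatter). For compound 4 the estimate in this assay is 300 nM, with a range from 90 nM to 1000 nM.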

Compound 4, half-maximal effective concentration: 0.2 nM
The estimate for compound 4 lay 1500-fold (3.18 log units) above the measured number; the measured number lies below the stated range.
By their numbers in this assay, from the lowest: compound 4; then compound 2; then compounds 1 and 3 (each within the scatter of the next).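

Among these compounds, on this amide-type nitrogen the earlier changes moved the number only modestly, yet 1H-pyrazol-5-yl gives a 4500-fold lower number from compound 3 to compound 4 (3.65 log units; beyond the scatter) and a 4500-fold lower number from compound 1 to compound 4 (3.65 log units; beyond the scatter) in this assay and so shows that this position can respond far more strongly than the earlier compounds suggested. An aromatic ring on this nitrogen is not enough by itself, since pyridin-2-yl also carries one and the change from it still gives a 1000-fold lower number from compound 2 to compound 4 (3.00 log units; beyond the scatter) at the same place. The counted hydrogen-bond donors and acceptors do not track the jump either, as 2-hydroxyethyl and 1H-pyrazol-5-yl have the same counts.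

Nothing measured here explains this gain. As far as these compounds go, it remains open whether the ring's hydrogen matters, which 1-methyl-1H-pyrazol-5-yl or a phenyl ring on the same nitrogen could help to show.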